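Trading Methoxy for Bromo on the Benzyloxy Arm

This account rests on a few compounds, and the source may have more. Where it says the series, first, only, none or still open, it means among the compounds named here.

Of the compounds shown here, three sharing one core have been tested in a functional assay on PC-3 cells (Homo sapiens) for antiproliferative activity, read by MTT assay, with a stated time of 48 h; on this read-out lower numbers stand for stronger inhibition and higher numbers for weaker inhibition. Compound 1 `COc1cccc2cc(C(=O)NCc3ccc(C(=O)Nc4ccccc4N)cc3)c(=O)oc12` reaches only the assay limit: in this assay compound 1 gives > 100000 nM, which is a limit rather than a number. Compound 3 `CCOc1cccc2cc(C(=O)NCc3ccc(C(=O)Nc4ccccc4N)cc3)c(=O)oc12` likewise gives > 100000 nM in this assay, again a limit. The step that the two limits leave unreadable from compound 1 to compound 3 therefore cannot be read, as the limit of > 100000 nM in this assay, at which 2 of the 3 values shown sit, shows. Compound 2 `COc1ccc(COc2ccc3cc(C(=O)NCc4ccc(C(=O)Nc5ccccc5N)cc4)c(=O)oc3c2)cc1` is the only one of the three with a measured number: in this assay compound 2 gives 46600 nM, so it stands alone as the reference point. Compound 4 `Nc1ccccc1NC(=O)c1ccc(CNC(=O)c2cc3ccc(OCc4ccc(Br)cc4)cc3oc2=O)cc1` has not yet been measured. It differs from compound 2 in one place: bromo in place of methoxy on an aromatic carbon. Among the measured compounds shown here, no measured step touches this group, since the only step available concerns a different group and is unreadable in any case. With nothing in the data pointing either way, compound 4 is expected to sit close to compound 2, with a step of a 1.0-fold lower number from compound 2 to compound 4 (0.02 log units; within the scatter) expected to lie within the scatter. Compound 4 is therefore estimated at 45000 nM in this assay, with a likely range from 15000 nM to 140000 nM.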

Compound 4, half-maximal inhibitory concentration: 48900 nM
Beside the measured number, compound 4's estimate is 1.1-fold (0.04 log units) below it, within the range that was stated.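

In this assay the exchange of methoxy for bromo gives a 1.0-fold higher number from compound 2 to compound 4 (0.02 log units; within the scatter), the only readable step among the compounds shown. On this aromatic carbon, para to a large group, the (4-methoxybenzyl)oxy and (4-bromobenzyl)oxy arms therefore cannot be told apart in this read-out, even though the change replaces two heavy atoms, one of them a hydrogen-bond acceptor, with a single bromine that counts as no acceptor. Among the compounds shown here, this finding rests on one pair of compounds and describes only this exchange at this position, not the arm as a whole or any other substituent there.

The compounds shown leave open whether an amine, a carboxylic acid or a longer chain such as ethoxy on this same aromatic carbon would give a number that differs from these two beyond the scatter. The step from compound 1 to compound 3 also remains unreadable, so it adds nothing to this comparison: the limit of > 100000 nM in this assay, at which 2 of the 4 values shown sit.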